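Series notes: phenyl and styryl analogues in paw edema assay

This account rests on a few compounds, and the source may have more. Where it says the series, first, only, none or still open, it means among the compounds named here.

Measured compounds:
compound 1, `O=C1N=C(C2C(=O)c3ccccc3C2=O)CC(c2ccccc2)N1`, 21%
compound 2, `O=C1N=C(C2C(=O)c3ccccc3C2=O)CC(c2ccc([N+](=O)[O-])cc2)N1`, 19%

Both compounds were read in a functional assay on the whole organism for inhibition, with Rattus norvegicus as the target, read by paw edema, with stated times of 30 min and 3 h, at a dose of 10 mg/kg by the oral route; a higher number here means more inhibition at the dose given (going by the name of the read-out), a lower number less inhibition. Compound 1 gives 21% and compound 2 gives 19%. For the measured compounds named here, the one step between them, a number 2 percentage points lower from compound 1 to compound 2 (within the scatter), means the two values cannot be told apart by this read-out, so compound 2 stands beside compound 1 rather than apart from it.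

Compound 3, `O=C1N=C(C2C(=O)c3ccccc3C2=O)CC(/C=C/c2ccccc2)N1`, is the next compound for this assay. It differs from compound 2 as follows: 2-phenylethenyl in place of 4-nitrophenyl on a saturated ring carbon.

Going by the values given here, no measured step involves a 2-phenylethenyl group, so nothing directly bears on this change. Among the compounds with values here, the only step available, a number 2 percentage points lower from compound 1 to compound 2 (within the scatter), concerns the nitro group on the aromatic carbon and shows that its presence or absence did not move the number beyond the scatter. With no guide to the new group, the working expectation is that compound 3 stays near compound 2, with a step of about a number 1 percentage points higher from compound 2 to compound 3 (within the scatter) expected in this assay. Compound 3 is therefore estimated at 20% in this assay. Going by these compounds, the expected range for compound 3 runs from 6% to 36%; the change is untested here, and the range is kept wide.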

Compound 3, a percentage reported as inhibition, in the whole organism at one dose (the size of the read-out at that dose, not a potency): 18%
The estimate for compound 3 lay 2 percentage points above the measured number, within the range that was stated.
By their numbers in this assay, from the lowest: compounds 3, 2 and 1 (each within the scatter of the next).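

Within this assay, the change now falls on the saturated ring carbon itself, next to the ring nitrogen, rather than on the aromatic ring as in the earlier nitro step. Replacing 4-nitrophenyl with 2-phenylethenyl gives one step (a number 1 percentage points lower from compound 2 to compound 3 (within the scatter)) and replacing phenyl with 2-phenylethenyl gives another (a number 3 percentage points lower from compound 1 to compound 3 (within the scatter)), so neither exchange separates the compounds in this read-out, even though the 2-phenylethenyl group places a double bond outside the aromatic ring and has 0 hydrogen-bond acceptors against 2 for 4-nitrophenyl. No supporting measurement bears on why the three compounds cannot be told apart.

All three readings are the size of the effect at one oral dose, so they say nothing about potency or about how the compounds would compare at other doses. Going by these compounds, it remains open whether an amine, a carboxylic acid or a longer saturated carbon chain on this saturated ring carbon would move the number beyond the scatter, or whether the position accepts such groups as it accepts phenyl, 4-nitrophenyl and 2-phenylethenyl.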